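Amide Variation at the Highest Measured Compound

The source may report more compounds than this note shows. Statements on the series, on what has been measured and on what is new or still open speak of the compounds shown alone.

Compound 1 `CCCCCCCCN(C)C(=O)Cn1cc(Cc2cnc(OC)nc2)c(=O)nc1SCc1ccc(F)cc1`: 39%
Compound 2 `CCCCCCCCN(C)C(=O)Cn1cc(Cc2cnc(OCC)nc2)c(=O)nc1SCc1ccc(F)cc1`: 23%
Compound 3 `CCCCCCCCN(C)C(=O)Cn1cc(Cc2cnc(=O)n(CC(=O)NC)c2)c(=O)nc1SCc1ccc(F)cc1`: 63%

In a functional assay on a cell-free system (plasma) for inhibition of platelet-activating factor acetylhydrolase (Homo sapiens), tested at 100 nM (on this read-out lower numbers stand for less inhibition and higher numbers for more inhibition at the one concentration tested (going by the name of the read-out)), compound 3 stands highest of the three measured compounds, reached from compound 1 by a number 24 percentage points higher from compound 1 to compound 3 (beyond the scatter) and from compound 2 by a number 40 percentage points higher from compound 2 to compound 3 (beyond the scatter). Compound 4 `CCCCCCCCN(C)C(=O)Cn1cc(Cc2cnc(=O)n(CC(=O)N3CCNC(=O)C3)c2)c(=O)nc1SCc1ccc(F)cc1` differs from compound 3 only at the amide: 3-oxopiperazin-1-yl in place of methylamino on a carbonyl carbon. Going by the values given here, none of the measured steps changes that amide; the two steps into compound 3 exchange the ring bound to the saturated chain carbon, and the step from compound 1 to compound 2 a number 16 percentage points lower from compound 1 to compound 2 (beyond the scatter) alters a chain on an oxygen. The data therefore give no direction for this change, and compound 4 is expected to show a number 3 percentage points lower from compound 3 to compound 4 (within the scatter), that is a value within the scatter of compound 3. Compound 4 is estimated at 60%, between 40% and 80%.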

Compound 4, a percentage reported as inhibition, at one concentration (the size of the read-out at that concentration, not a potency): 80%
For compound 4 the middle estimate is 20 percentage points below the measured one; the range from low to high includes it.
By their numbers in this assay, from the lowest: compound 2; then compound 1; then compound 3; then compound 4.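

The earlier steps shown here left the amide untouched, and this one shows that it matters: in this assay, 3-oxopiperazin-1-yl in place of methylamino on the carbonyl carbon gives (a number 17 percentage points higher from compound 3 to compound 4 (beyond the scatter)). This position therefore accepts a larger group that contains a ring, and the inhibition at the one tested concentration still rises. No supporting measurement bears on the reason for this rise.

As far as these compounds go, whether the gain depends on the ring or on its carbonyl remains open. A plain piperazin-1-yl or morpholin-4-yl group at this amide would help separate the two.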